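This account rests on a few compounds, and the source may have more. Where it says the series, first, only, none or still open, it means among the compounds named here.

Measured compounds:
compound 1 `CO/N=C(\CCN1CCN(c2ccccn2)CC1)c1ccccc1C` — 80%
compound 2 `CO/N=C(\CCN1CCN(c2ccccn2)CC1)c1ccc(Cl)cc1Cl` — 78%

Among the compounds with values here, in a functional assay on HEK293 cells with D(4) dopamine receptor (Homo sapiens) as the target, read by FLIPR (on this read-out higher numbers stand for larger maximal responses and lower numbers for smaller maximal responses), compound 2 gives 78%, the lower of the two numbers at hand, though the only neighbour, compound 1 at 80%, sits within the scatter of it, so the two cannot be told apart. The next compound, compound 3 `CO/N=C(\CCN1CCN(c2ccccn2)CC1)c1ccc(Cl)c(Cl)c1`, differs from compound 2 in one place: 3,4-dichlorophenyl in place of 2,4-dichlorophenyl on a carbon with a double bond to nitrogen. Within the data shown here, the single measured step that touches the aryl group on the carbon with a double bond to nitrogen is a number 2 percentage points lower from compound 1 to compound 2 (within the scatter), which stayed within the scatter despite exchanging one aryl for another. Among the measured compounds shown here, no measured pair moves a chlorine within a dichlorophenyl. On that basis the writer expects no step beyond the scatter in this assay for compound 3, and the estimated step is no change at the digits printed from compound 2 to compound 3 (within the scatter). Compound 3 is therefore estimated at 78%, with a range from 62% to 92%.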

Compound 3, largest response reached (reported as efficacy), in percent of the reference or control that the assay uses: 79%
Compound 3: middle estimate off by 1 percentage points, on the low side, and the stated range covers the measured number.
By their numbers in this assay, from the lowest: compounds 2, 3 and 1 (each within the scatter of the next).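

In this assay, moving from 2,4-dichlorophenyl to 3,4-dichlorophenyl on the carbon with a double bond to nitrogen gives a number 1 percentage points higher from compound 2 to compound 3 (within the scatter), so this pair shows that rearranging the same atoms within the dichlorophenyl group leaves no difference that this read-out can resolve. Placing 3,4-dichlorophenyl where compound 1 carries 2-methylphenyl gives a number 1 percentage points lower from compound 1 to compound 3 (within the scatter), which extends the earlier finding: all three aryl groups at this place give responses that cannot be told apart. Nothing available accounts for this lack of difference.

The compounds shown leave open whether the response would hold with a phenyl ring bearing an amine or a carboxylic acid. They also leave open what a non-aromatic group, such as a cyclohexyl ring, would do at this place.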